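The source may hold more compounds than are shown below. What is called first, only, known or untested is meant among the compounds shown, and "the series" means these compounds.

Working notes on the series.

Compound 1 `Cc1ccc(-c2n[nH]cc2N2CCCNCC2)cc1` carries a methyl on the aromatic ring attached to the shared core. In an assay on isolated protein for binding affinity to 5-hydroxytryptamine receptor 4 (Homo sapiens) (a lower number here means a stronger inhibitor, a higher number a weaker inhibitor), compound 1 gives > 10000 nM, which is a limit of the assay and not a number. Compound 2 `Fc1cccc(-c2n[nH]cc2N2CCCNCC2)c1` carries a fluorine on that ring instead. In this assay compound 2 gives > 10000 nM, again a limit rather than a number. Going by the values given here, both values sit at the limit of > 10000 nM in this assay, at which 2 of the 2 values shown sit, so compound 1 stands where every value shown stands, and no step between measured compounds can be sized: the pair tells only that neither reaches a measurable inhibition constant.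

Compound 3 `COc1ccc(-c2n[nH]cc2N2CCCNCC2)cc1` differs from compound 1 by methoxy in place of methyl on an aromatic carbon. Among the compounds with values here, no measured step covers this change in this assay, and the two values at hand give no direction for it. The expectation is therefore no step beyond the scatter, with compound 3 most likely remaining at a limit. In this assay compound 3 is estimated at 15000 nM, with a range from 3000 nM to 80000 nM. This estimate implies a step that the limit leaves unreadable from compound 1 to compound 3, expected to be within the scatter.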

Compound 3, inhibition constant: > 10000 nM
Compound 3: only a limit was reported (the forecaster's own chance of this, stated with the estimate: 80%); the middle value does not contradict the limit.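

In this assay compound 3 gives > 10000 nM as a limit of the assay and not a number. Going by these compounds alone, no step between compound 1 and compound 3 can be read: (the limit of > 10000 nM in this assay, at which 3 of the 3 values shown sit). The compounds shown leave open whether any substituent on the aromatic ring attached to the shared core reaches a measurable inhibition constant.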